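Swapping the Fluorophenyl Group for Naphthalene

The compounds below may be only part of what the source reports. "The series", "measured", "known", "first", "only" and "open" are said of these compounds alone.

compound 1 `Nc1ccccc1NC(=O)/C=C/c1ccc(CSc2ccc(Cl)cc2)cc1` gives 59.6%
compound 2 `CCc1ccc(SCc2ccc(/C=C/C(=O)Nc3ccccc3N)cc2)cc1` gives 68.6%
compound 3 `Nc1ccccc1NC(=O)/C=C/c1ccc(CSc2ccc(F)cc2)cc1` gives 59.1%

In a functional assay on A549 cells (Homo sapiens) for inhibition, read by CCK-8 assay, with a stated time of 72 h, tested at 8 uM (on this read-out lower numbers stand for less inhibition of growth and higher numbers for more inhibition of growth at the one concentration tested), compound 3 at 59.1% lies within the scatter of both other compounds. Compound 4 `Nc1ccccc1NC(=O)/C=C/c1ccc(CSc2cccc3ccccc23)cc1` has naphthalen-1-yl in place of 4-fluorophenyl on a sulfur is a larger change than any measured so far. The measured swaps of one group on an aromatic carbon gave a number 0.5 percentage points lower from compound 1 to compound 3 (within the scatter) and a number 9 percentage points higher from compound 1 to compound 2 (within the scatter) and a number 9.5 percentage points lower from compound 2 to compound 3 (within the scatter) so they bear on it only loosely. None replaces a whole ring, so no shift beyond the scatter is firmly expected. The expected size is a number 4.9 percentage points higher from compound 3 to compound 4 (within the scatter) and that direction is uncertain. For compound 4 the estimate is 64% with an expected range from 45% to 80%.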

Compound 4, percent growth inhibition at one concentration: 71.2%
Compound 4: the middle estimate sits 7.2 percentage points below what was measured, within the range that was stated.
By their numbers in this assay, from the lowest: compounds 3, 1, 2 and 4 (each within the scatter of the next, the first and the last beyond it).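

In this assay, among these compounds, the swap to naphthalen-1-yl on the sulfur gives the first steps beyond the scatter, with a number 12.1 percentage points higher from compound 3 to compound 4 (beyond the scatter) and a number 11.6 percentage points higher from compound 1 to compound 4 (beyond the scatter) as the two modest gains. Against the ethyl compound, however, a number 2.6 percentage points higher from compound 2 to compound 4 (within the scatter) stays within the scatter, so the second aromatic ring beats the halogen-bearing rings but not 4-ethylphenyl. Nothing available explains this gain.

Still open, going by these compounds, is whether a phenyl ring carrying an amine or a carboxylic acid would be accepted on this sulfur. Whether naphthalen-2-yl would match naphthalen-1-yl is also unanswered.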